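Formyl versus hydroxymethyl on the chain in two cores

The source may hold more compounds than are shown below. What is called first, only, known or untested is meant among the compounds shown, and "the series" means these compounds.

Measured in an assay on 32D cells for inhibition of interleukin-15 (Mus musculus), read by resazurin assay, with stated times of 30 min and 2.5 days, in the presence of a further agent that is not named here; a higher number here means a weaker inhibitor, a lower number a stronger inhibitor:
- compound 1, `Cn1nc(Cc2nnc(SCC(=O)Nc3ccc(Cl)cc3Cl)n2CCC=O)c2ccccc2c1=O`: 6400 nM
- compound 2, `Cn1nc(Cc2nnc(SCC(=O)Nc3ccc(Cl)cc3Cl)n2CCCO)c2ccccc2c1=O`: in this assay compound 2 reaches only the limit of the assay, > 30000 nM, and no number.
- compound 3, `Cn1c(Cc2nn(CCC=O)c(=O)c3ccccc23)nnc1SCC(=O)Nc1ccc(Cl)cc1Cl`: 30000 nM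

The series carries one chain change on two cores. Compound 1 and compound 3 have the same atoms joined differently; the difference between the two cores is not broken down here. Of the two numbers in hand, compound 3 stands higher, compound 1 lower, the gap being beyond the scatter.

The change itself, (hydroxymethyl in place of formyl on a saturated chain carbon, two bonds along the chain from an aromatic nitrogen), gives in this assay an at least 4.6-fold higher number from compound 1 to compound 2 (0.67 log units; beyond the scatter), where the second value is a limit, (the limit of > 30000 nM in this assay, at which 1 of the 3 values shown sits), so the true size of that step is open upward.

Compound 4, `Cn1c(Cc2nn(CCCO)c(=O)c3ccccc23)nnc1SCC(=O)Nc1ccc(Cl)cc1Cl`, is the same change on the core of compound 3: hydroxymethyl in place of formyl on a saturated chain carbon, two bonds along the chain from an aromatic nitrogen. The place lines of the two changes read alike, so this is the same change, not merely one of the same kind. Since compound 3 already stands at the highest measured number, the step is expected to carry compound 4 past the point where the assay still returns a number; the expected step is a 2.0-fold higher number from compound 3 to compound 4 (0.30 log units; within the scatter), resting on an at least 4.6-fold higher number from compound 1 to compound 2 (0.67 log units; beyond the scatter). Compound 4 is estimated at 60000 nM, within 30000 nM to 150000 nM, with a limit report the most likely outcome.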

Compound 4, half-maximal inhibitory concentration: > 30000 nM
Compound 4: a limit, no number (the forecaster's own chance of this, stated with the estimate: 75%); the middle value does not contradict the limit.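

In this assay compound 4 gives > 30000 nM, which is a limit of the assay and not a number. Replacing formyl with hydroxymethyl on the other core gives a number no lower from compound 3 to compound 4 (the limit leaves the size open), but the size of the new step cannot be read, so the comparison goes no further than direction: the same change on two cores in this assay, an at least 4.6-fold higher number (0.67 log units; beyond the scatter) from compound 1 to compound 2 and a number no lower (the limit leaves the size open) from compound 3 to compound 4; the limit leaves it open whether they differ The data do not show that the change carries over from one core to the other with the same size, nor that its size differs, and the limit also bounds the earlier step on one side only: the limit of > 30000 nM in this assay, at which 2 of the 4 values shown sit.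

On these data alone, the true size of both steps remains open, as neither compound with hydroxymethyl on the chain returns a number in this assay. The compounds shown also leave open how the chain behaves with a carboxylic acid, an amine or a longer chain in place of formyl, and whether any such group would carry over from one core to the other or match compound 1, which gives 6400 nM.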